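Swapping one anilide ring for another in a cyclopropane diamide

A few compounds are considered here, and "the series" means these few. Any claim that something is new, unique, unknown or untested is made for them only; others in the source may bear on it.

Measured compounds and their values in a functional assay on T47D cells (Homo sapiens) for inhibition, read by CCK-8 assay, with a stated time of 72 h, tested at 10 uM; a lower number here means less inhibition of growth, a higher number more inhibition of growth at the concentration tested:
- compound 1, `CN(C)C(=O)c1cc2cnc(Nc3ccc(NC(=O)C4(C(=O)Nc5ccccc5)CC4)cc3)nc2n1C1CCCC1`: 93.9%
- compound 2, `CN(C)C(=O)c1cc2cnc(Nc3ccc(NC(=O)C4(C(=O)Nc5ccc(Cl)c(C(F)(F)F)c5)CC4)cc3)nc2n1C1CCCC1`: 55.8%
- compound 3, `CN(C)C(=O)c1cc2cnc(Nc3ccc(NC(=O)C4(C(=O)Nc5cccc(Cl)c5)CC4)cc3)nc2n1C1CCCC1`: 92.6%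

Compound 3 stands second highest of the three; compound 1 sits within the scatter of it, while compound 2 lies far lower. Two measured steps describe how the ring on the amide-type nitrogen matters here: a number 1.3 percentage points lower from compound 1 to compound 3 (within the scatter) shows that a single chloro on that ring leaves the number essentially unchanged, whereas a number 38.1 percentage points lower from compound 1 to compound 2 (beyond the scatter) and a number 36.8 percentage points higher from compound 2 to compound 3 (beyond the scatter) show that the doubly substituted ring costs a great deal.

Compound 4, `Cc1ccc(NC(=O)C2(C(=O)Nc3ccc(Nc4ncc5cc(C(=O)N(C)C)n(C6CCCC6)c5n4)cc3)CC2)cc1`, has not yet been measured in this assay. Its difference from compound 3 is 4-methylphenyl in place of 3-chlorophenyl on an amide-type nitrogen. Going by the values given here, no measured step covers a methyl on this ring, so the expectation rests on analogy: a single small substituent, as in compound 3 with 92.6% and compound 1 with 93.9%, has so far changed little, and only the heavier two-group ring of compound 2 has lowered growth inhibition. The step from compound 3 to compound 4 is therefore expected to stay within the scatter, a number 4.6 percentage points lower from compound 3 to compound 4 (within the scatter), perhaps slightly downward. Compound 4 is estimated at 88%, within a range of 70% to 97%.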

Compound 4, percent growth inhibition at one concentration: 99.6%
Estimate against measurement, compound 4: 11.6 percentage points below, outside the stated range (above it).
By their numbers in this assay, from the lowest: compound 2; then compounds 3, 1 and 4 (each within the scatter of the next).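

In this assay, a methyl on this ring leaves the picture unchanged, with a number 5.7 percentage points higher from compound 1 to compound 4 (within the scatter) and a number 7 percentage points higher from compound 3 to compound 4 (within the scatter), so the phenyl, 3-chlorophenyl and 4-methylphenyl rings cannot be told apart at the concentration tested. The earlier compounds had shown this tolerance for only one small group, and it now extends to a second group of a different kind, placed differently on the ring. The 4-chloro-3-(trifluoromethyl)phenyl ring remains the only one that stands apart, with a number 43.8 percentage points higher from compound 2 to compound 4 (beyond the scatter), which shows that a single 4-substituent of this kind does not bring the loss, although nothing measured here explains why that two-group ring behaves differently.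

The compounds shown do not separate the roles of the two groups on that ring, a question that 4-chlorophenyl and 3-(trifluoromethyl)phenyl rings, each carrying one of those groups alone, would address. Going by these compounds, how far the tolerance reaches also stays open, since a ring bearing a carboxylic acid, an amine or a longer chain such as butyl could give a very different result.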